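The source may report more compounds than this note shows. Statements on the series, on what has been measured and on what is new or still open speak of the compounds shown alone.

Measured compounds:
- compound 1, `CC[C@@H](Nc1c(C#N)c(-c2ccc(-c3cccc(OC)c3)cc2)nc2cnccc12)C(N)=O`, gives 104 nm/s in an ADME assay on Caco-2 cells (Homo sapiens) for permeability, read by LC-MS, in the apical to basolateral direction, with a stated time of 2 h, tested at 2 uM; on this read-out higher numbers stand for higher permeability and lower numbers for lower permeability
- compound 2, `CC[C@@H](Nc1c(C#N)c(-c2ccc(-c3ccccc3OC)cc2)nc2cnccc12)C(N)=O`, gives 160 nm/s in this assay

Compound 2 holds the higher of the two numbers, yet it is not separated from compound 1 by more than the usual scatter: the change from compound 1 to compound 2 was a 1.5-fold higher number from compound 1 to compound 2 (0.19 log units; within the scatter). Compound 3, `CC[C@@H](Nc1c(C#N)c(-c2ccc(-c3cccc(Cl)c3F)cc2)nc2cnccc12)C(N)=O`, is the next compound to be tested. It differs from compound 2 in one place: 3-chloro-2-fluorophenyl in place of 2-methoxyphenyl on an aromatic carbon. Among the measured compounds shown here, no measured step covers an exchange of this kind; the only step seen so far, a 1.5-fold higher number from compound 1 to compound 2 (0.19 log units; within the scatter), moves a methoxy group on the same kind of ring and stays within the scatter. With nothing pointing in either direction, the expected change from compound 2 to compound 3 is a 1.1-fold higher number from compound 2 to compound 3 (0.03 log units; within the scatter), none beyond the scatter. Compound 3 is therefore estimated at 170 nm/s in this assay, with a range of 85 nm/s to 340 nm/s.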

Compound 3, apparent permeability: 39 nm/s
The estimate for compound 3 lay 4.4-fold (0.64 log units) above the measured number, outside the stated range (below it).
By their numbers in this assay, from the lowest: compound 3; then compounds 1 and 2 (each within the scatter of the next).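

In this assay, the group at this position, on an aromatic carbon para to a large group, clearly matters: 3-chloro-2-fluorophenyl gives a 4.1-fold lower number from compound 2 to compound 3 (0.61 log units; beyond the scatter) when it replaces 2-methoxyphenyl, and a 2.7-fold lower number from compound 1 to compound 3 (0.43 log units; beyond the scatter) when it replaces 3-methoxyphenyl. Moving the methoxy group had stayed within the scatter, so this exchange of substituents is the first change here to shift the number beyond it. Nothing measured here explains the drop. Going by these compounds, the exchange removes the methoxy group and adds two halogens at once, so it remains open whether the chlorine, the fluorine or the loss of the methoxy group accounts for the step. The compounds shown also leave open how an aminomethyl group or a carboxylic acid on this ring would read in this assay.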